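The source may hold more compounds than are shown below. What is called first, only, known or untested is meant among the compounds shown, and "the series" means these compounds.

Working notes on the series. Compound 1 `Cc1ccc(/C=C2\CN(C(=S)SCc3cn(Cc4ccc(F)cc4)nn3)C/C(=C\c3ccc(C)cc3)C2=O)cc1` and compound 2 `Cc1ccc(/C=C2\CN(C(=S)SCc3cn(Cc4ccccc4F)nn3)C/C(=C\c3ccc(C)cc3)C2=O)cc1` share a core and differ in one place. In a functional assay on MCF7 cells (Homo sapiens) for cytotoxicity, read by MTT assay, with a stated time of 24 h (a lower number here means a stronger inhibitor, a higher number a weaker inhibitor), compound 1 gives 81600 nM. For compound 2 this assay records only a limit, > 100000 nM, and the line the limit of > 100000 nM in this assay, at which 1 of the 3 values shown sits, marks that this value is one of the limit readings. The change from compound 2 to compound 1 is 4-fluorophenyl in place of 2-fluorophenyl on a saturated chain carbon bound to an aromatic nitrogen, and it gave an at least 1.2-fold lower number from compound 2 to compound 1 (0.08 log units; that floor lies within the scatter). Compound 3 `O=C1/C(=C/c2ccccc2F)CN(C(=S)SCc2cn(Cc3ccccc3F)nn2)C/C1=C\c1ccccc1F` carries a different core; the difference between the core of compound 3 and that of compound 2 is not broken down here. In this assay compound 3 gives 51600 nM. Compound 4 `O=C1/C(=C/c2ccccc2F)CN(C(=S)SCc2cn(Cc3ccc(F)cc3)nn2)C/C1=C\c1ccccc1F` is not yet measured; it is derived from compound 3 by the same change, (4-fluorophenyl in place of 2-fluorophenyl on a saturated chain carbon bound to an aromatic nitrogen). For compound 4 the expected step is a 1.3-fold lower number from compound 3 to compound 4 (0.11 log units; within the scatter), resting on the step seen from compound 2 to compound 1, an at least 1.2-fold lower number from compound 2 to compound 1 (0.08 log units; that floor lies within the scatter), which sits within the scatter. Compound 4 is therefore estimated at 40000 nM, with the expected range running from 15000 nM to 100000 nM.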

Compound 4, half-maximal inhibitory concentration: 56900 nM
For compound 4 the middle estimate is 1.4-fold (0.15 log units) below the measured one, and the stated range covers the measured number.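

In this assay, the change from 2-fluorobenzyl to 4-fluorobenzyl on the core of compound 3 gives a 1.1-fold higher number from compound 3 to compound 4 (0.04 log units; within the scatter), so on this core the swap leaves the reading within the scatter. Whether the change carries over from one core to the other with the same size is not settled: the same change on two cores in this assay, an at least 1.2-fold lower number (0.08 log units; that floor lies within the scatter) from compound 2 to compound 1 and a 1.1-fold higher number (0.04 log units; within the scatter) from compound 3 to compound 4; the limit leaves it open whether they differ. The reading of compound 2 is a limit of the assay and not a number, so the earlier step gives only a floor, and the pair of steps shows no firm agreement or disagreement between the cores: the limit of > 100000 nM in this assay, at which 1 of the 4 values shown sits.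

The compounds shown leave open how the reading responds when the fluorobenzyl group gives way to an unsubstituted benzyl, a chlorobenzyl or a longer chain ending in an amine. They also leave open whether the swap from 2-fluorobenzyl to 4-fluorobenzyl would stay within the scatter on any core beyond these two.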